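The source may report more compounds than this note shows. Statements on the series, on what has been measured and on what is new or still open speak of the compounds shown alone.

Measured so far:
compound 1 `CC1CCn2c(ncc(C(=O)O)c2=O)/C1=N/Nc1ccccc1` — 32 umol/kg
compound 2 `CC1CC/C(=N\Nc2cccc(Cl)c2)c2ncc(C(=O)O)c(=O)n21` — 0.6 umol/kg
compound 3 `CC1CC/C(=N\Nc2cccc(Br)c2)c2ncc(C(=O)O)c(=O)n21` — 0.4 umol/kg

In a functional assay on the whole organism for inhibition, with Rattus norvegicus as the target (on this read-out higher numbers stand for an effect only at larger amounts of compound and lower numbers for an effect already at smaller amounts), compound 3 gives 0.4 umol/kg, the lowest of the three numbers. Compound 2 is nearest with 0.6 umol/kg; the step of a 1.5-fold lower number from compound 2 to compound 3 (0.18 log units; within the scatter) stays within the scatter, so the two are not separated. Compound 1, the unsubstituted phenyl, gives 32 umol/kg, and its gap to compound 3 lies well beyond the scatter.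

Compound 4 `COc1ccc(N/N=C2\CCC(C)n3c2ncc(C(=O)O)c3=O)cc1` is the next member. Relative to compound 3 the change is 4-methoxyphenyl in place of 3-bromophenyl on an amine nitrogen. Within the data shown here, no measured step bears on it directly: the only step on record exchanges one halogen for another on the same aromatic carbon and is within the scatter. What the series does show is that compound 1, with an unsubstituted phenyl, sits far above compounds 2 and 3. Compound 4 carries a substituent, but neither a halogen nor one on the same carbon as in compounds 2 and 3, so its number is uncertain; it is expected to land between the values of compound 1 and compound 3, with the step of a 15-fold higher number from compound 3 to compound 4 (1.18 log units; beyond the scatter) from compound 3 being a rise. Compound 4 is therefore estimated at 6 umol/kg, in the range 1.5 umol/kg to 30 umol/kg.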

Compound 4, dose for 50% inhibition: 0.8 umol/kg
Compound 4: the middle estimate sits 7.5-fold (0.88 log units) above what was measured; the measured number lies below the stated range.
By their numbers in this assay, from the lowest: compounds 3, 2 and 4 (each within the scatter of the next); then compound 1.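

In this assay the exchange of 3-bromophenyl for 4-methoxyphenyl on an amine nitrogen gives a 2.0-fold higher number from compound 3 to compound 4 (0.30 log units; within the scatter) and the exchange of 3-chlorophenyl for the same group gives a 1.3-fold higher number from compound 2 to compound 4 (0.12 log units; within the scatter) so neither change separates compound 4 from its halogen-bearing partners. Among these four compounds, low numbers are therefore not confined to a halogen on the phenyl ring: compound 4 gives 0.8 umol/kg against the unsubstituted phenyl of compound 1 at 32 umol/kg and no compound shown goes against this. No measurement at hand bears on what lies behind this result.

Both the identity of the substituent and its place on the phenyl ring change in these steps, so the compounds shown cannot separate the two, and a 4-chlorophenyl or 3-methoxyphenyl group would be needed to do so. Also open, on these data alone, is whether the numbers hold with a dimethylamino group or a nitrile on the phenyl ring, or with an ethyl ester in place of the carboxylic acid on the shared core.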